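The compounds below may be only part of what the source reports. "The series", "measured", "known", "first", "only" and "open" are said of these compounds alone.

Three compounds share a common core and differ only in the group that sits on the aromatic ring bearing the trifluoromethyl group. In an assay on CHO cells for antagonist activity at transient receptor potential cation channel subfamily V member 1 (Homo sapiens), read by FLIPR (on this read-out lower numbers stand for stronger inhibition and higher numbers for weaker inhibition), compound 1 `CC(C(=O)NCc1ccc(C(F)(F)F)cc1N1CCC(Cc2ccccc2)CC1)c1ccc(NS(C)(=O)=O)c(F)c1` gives 1.4 nM. In this assay compound 2 `CCCCCCOc1cc(C(C)(F)F)ccc1CNC(=O)C(C)c1ccc(NS(C)(=O)=O)c(F)c1` gives 0.8 nM. Compound 3 `CC(C)CCOc1cc(C(F)(F)F)ccc1CNC(=O)C(C)c1ccc(NS(C)(=O)=O)c(F)c1` gives 0.5 nM in this assay, the lowest of the three numbers; its gap to compound 2 stays within the usual scatter, while its gap to compound 1 lies beyond it, so only against compound 1 can compound 3 be called the stronger inhibitor.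

Compound 4 `CC(C(=O)NCc1ccc(C(F)(F)F)cc1-c1ccc(C(C)(C)C)cc1)c1ccc(NS(C)(=O)=O)c(F)c1` has not been measured. The change from compound 3 to compound 4 is 4-(tert-butyl)phenyl in place of isopentyloxy on an aromatic carbon. Among the measured compounds, compound 1 is the one that carries a ring-containing group at this place rather than an alkoxy chain, and its number is close to those of compounds 2 and 3. An expected step from compound 3 to compound 4 of a 3.0-fold higher number from compound 3 to compound 4 (0.48 log units; beyond the scatter) therefore seems reasonable, a small move toward a higher number, near the edge of the scatter, because compound 1 carries a ring group there and gives 1.4 nM. Compound 4 is expected to give about 1.5 nM in this assay, with a likely range from 0.4 nM to 6 nM.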

Compound 4, inhibition constant: 1.1 nM
Estimate against measurement, compound 4: 1.4-fold (0.13 log units) above; measured number inside the range.
By their numbers in this assay, from the lowest: compounds 3, 2, 4 and 1 (each within the scatter of the next, the first and the last beyond it).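

For the compounds shown here, compound 3 and compound 4 are the only pair here that differ in just one place, so this is the first direct reading of a change at this aromatic carbon: in this assay, 4-(tert-butyl)phenyl in place of isopentyloxy gives a 2.2-fold higher number from compound 3 to compound 4 (0.34 log units; beyond the scatter) and the step is modest. The entering group has more heavy atoms, is all carbon, brings a six-membered aromatic ring and has no hydrogen-bond acceptor, yet compound 4 still gives 1.1 nM in this assay and so stays a strong inhibitor on this read-out, which shows that neither an alkoxy chain nor its oxygen is essential here for a low number. Nothing shown here explains why the number rises with this change.

This single step swaps the oxygen, the chain and the ring all at once, so their separate contributions stay unresolved; a plain phenyl ring without the tert-butyl, or a benzyloxy group, would help to pull them apart. On these data alone, how this position responds to a charged group such as a carboxylic acid or a small primary amine also remains open.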